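The source may hold more compounds than are shown below. What is called first, only, known or untested is meant among the compounds shown, and "the series" means these compounds.

Working notes on the series, followed in an in vitro assay on BHK cells for displacement of a labelled ligand from Glucagon receptor (Homo sapiens), read by scintillation proximity assay; on this read-out lower numbers stand for stronger inhibition and higher numbers for weaker inhibition. Compound 1 `O=C(O)CCNC(=O)c1ccc(CN(c2ccc3c(c2)CCC3)c2nc(-c3ccc(C(F)(F)F)cc3)cs2)cc1` gives 86 nM in this assay. Compound 2 `O=C(O)CCNC(=O)c1ccc(CN(c2ccc(C3=CCCCC3)cc2)c2nc(-c3ccc(Cl)cc3)c(-c3ccccc3)s2)cc1` gives 86 nM, level with compound 1 at the digits shown, and the two together are the lowest of the three numbers. Compound 3 `O=C(O)CCNC(=O)c1ccc(CC(c2ccc(Cl)cc2)c2nc(-c3ccc(C(F)(F)F)cc3)cs2)cc1` gives 96 nM, within the scatter of compound 1. For the measured compounds named here, no two measured compounds differ in only one place, so no single structural step can be read from these values. Compound 4 `O=C(O)CCNC(=O)c1ccc(CN(c2ccc(SC(F)(F)F)cc2)c2nc(-c3ccc(C(F)(F)F)cc3)cs2)cc1` is not yet measured; it differs from compound 1 by 4-((trifluoromethyl)sulfanyl)phenyl in place of 2,3-dihydro-1H-inden-5-yl on a nitrogen on an aromatic ring. Nothing in the measured set speaks for a shift in either direction from this change, so the step is expected to stay within the scatter, a 1.0-fold lower number from compound 1 to compound 4 (0.01 log units; within the scatter). Compound 4 is estimated at 85 nM, between 30 nM and 250 nM.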

Compound 4, half-maximal inhibitory concentration: 34 nM
The estimate for compound 4 lay 2.5-fold (0.40 log units) above the measured number; low and high end bracket the measured number.
By their numbers in this assay, from the lowest: compound 4; then compounds 1, 2 and 3 (each within the scatter of the next).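

At this position, on a nitrogen on an aromatic ring, 4-((trifluoromethyl)sulfanyl)phenyl in place of 2,3-dihydro-1H-inden-5-yl gives a 2.5-fold lower number from compound 1 to compound 4 (0.40 log units; beyond the scatter) in this assay and so moves the number beyond the scatter. For the compounds shown here, this is the only step that can be read, and it shows that the group at this position can change the read-out. No measurement on hand accounts for the shift.

Going by these compounds, whether the sulfur, the trifluoromethyl or the loss of the five-membered ring carries the change stays open. A 4-(trifluoromethyl)phenyl or a 4-methoxyphenyl group at this position would help to separate these parts.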